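Swapping the quinazolinyl arm for benzyl in compound 4

The compounds below may be only part of what the source reports. "The series", "measured", "known", "first", "only" and "open" are said of these compounds alone.

Compound 1 `Cc1cc(Nc2ccn(Cc3nc(C)c4ccccc4n3)n2)n2nc(SCc3ccc(Br)cc3)nc2n1`: 36800 nM
Compound 2 `Cc1cc(Nc2cc(-c3cccs3)[nH]n2)n2nc(SCc3ccc(Br)cc3)nc2n1`: 38700 nM
Compound 3 `Cc1cc(Nc2cc(-c3ccc(F)cc3)[nH]n2)n2nc(SCc3ccc(Br)cc3)nc2n1`: 34200 nM

Of the compounds shown here, three share one core and have been tested in an ADME assay on GES1 cells (Homo sapiens) for inhibition, read by MTT assay, with a stated time of 72 h; a higher number here means a weaker inhibitor, a lower number a stronger inhibitor. Compound 1 gives 36800 nM in this assay, which stands second highest of the three numbers; its neighbours are compound 2 at 38700 nM and compound 3 at 34200 nM, and both sit within the scatter of compound 1, so no order among the three can be drawn. Among the measured compounds shown here, the single step between measured compounds, a 1.1-fold lower number from compound 2 to compound 3 (0.05 log units; within the scatter), concerns a different position and is itself within the scatter.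

Compound 4 `Cc1cc(Nc2ccn(Cc3ccccc3)n2)n2nc(SCc3ccc(Br)cc3)nc2n1` has not yet been measured. It differs from compound 1 by phenyl in place of 4-methylquinazolin-2-yl on a saturated chain carbon bound to an aromatic nitrogen. For the measured compounds named here, no measured step touches this position, so nothing in the data points to a change beyond the scatter. Compound 4 is therefore expected to give about 37000 nM in this assay, with a range from 15000 nM to 90000 nM. That estimate means a step of a 1.0-fold higher number from compound 1 to compound 4 (0.00 log units; within the scatter), expected to stay within the scatter.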

Compound 4, half-maximal inhibitory concentration: 44400 nM
The estimate for compound 4 lay 1.2-fold (0.08 log units) below the measured number; the measured number falls inside the stated range.
By their numbers in this assay, from the lowest: compounds 3, 1, 2 and 4 (each within the scatter of the next).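

The step at this position, phenyl in place of 4-methylquinazolin-2-yl on a saturated chain carbon bound to an aromatic nitrogen, gives in this assay a 1.2-fold higher number from compound 1 to compound 4 (0.08 log units; within the scatter). The earlier compounds shown here held no measured step at this position, and this one shows that the much larger 4-methylquinazolin-2-yl, with its two aromatic rings and its hydrogen-bond acceptors, can give way to a plain phenyl without the number moving beyond the scatter. Nothing at hand gives a reason for this result.

The compounds shown leave open whether any group at this position can move the number beyond the scatter, since both groups tested here give numbers within it. An amine, a carboxylic acid or a longer chain in place of the phenyl could test that.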